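Swapping fluoro for chloro on compound 1

The source may report more compounds than this note shows. Statements on the series, on what has been measured and on what is new or still open speak of the compounds shown alone.

Measured so far:
compound 1 `CCC(CC)n1c(-c2ccc(OCc3c(-c4c(Cl)cccc4Cl)noc3C(C)C)cc2F)nc2ccc(C(=O)O)cc21` – 1.3 nM
compound 2 `CC(C)c1onc(-c2c(Cl)cccc2Cl)c1COc1ccc(-c2nc3ccc(C(=O)O)cc3n2CC2CCCCC2)c(F)c1` – 7.8 nM

Both compounds were tested in an assay on Huh-7 cells for agonist activity at Bile acid receptor (Homo sapiens), read by a luciferase reporter; on this read-out higher numbers stand for an effect only at larger amounts of compound and lower numbers for an effect already at smaller amounts. Compound 1 gives the lowest of the two numbers; its nearest neighbour is compound 2, and the step of a 6.0-fold higher number from compound 1 to compound 2 (0.78 log units; beyond the scatter) is modest but beyond the scatter. That step changes only the group on the aromatic nitrogen of the shared core.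

Compound 3 `CCC(CC)n1c(-c2ccc(OCc3c(-c4c(Cl)cccc4Cl)noc3C(C)C)cc2Cl)nc2ccc(C(=O)O)cc21` has not yet been measured. It differs from compound 1 in one place: chloro in place of fluoro on an aromatic carbon. Fluoro and chloro are both halogens of similar size, and the change sits on the aryl ring rather than on the aromatic nitrogen where the only measured step lies. Among the compounds with values here, no measured step therefore bears directly on this change, and nothing in the two values points one way or the other.

On that basis compound 3 is expected to give a number close to that of compound 1, with the step of a 1.5-fold higher number from compound 1 to compound 3 (0.19 log units; within the scatter) as the estimate, most likely within the scatter. The estimate for compound 3 in this assay is 2 nM, in a range from 0.6 nM to 7 nM.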

Compound 3, half-maximal effective concentration: 1.6 nM
Compound 3: middle estimate off by 1.3-fold (0.10 log units), on the high side; low and high end bracket the measured number.
By their numbers in this assay, from the lowest: compounds 1 and 3 (each within the scatter of the next); then compound 2.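

In this assay, chloro in place of fluoro on this aromatic carbon, ortho to a large group and meta to a large group, gives a 1.2-fold higher number from compound 1 to compound 3 (0.09 log units; within the scatter) and so leaves the two compounds indistinguishable on this read-out. Within the data shown here, this is the first look at this aromatic carbon, since the only earlier comparison concerned the group on the aromatic nitrogen, where a 6.0-fold higher number from compound 1 to compound 2 (0.78 log units; beyond the scatter) was a real difference; on the core of compound 1, fluoro and chloro are interchangeable here as far as this read-out can tell. No independent measurement is available to show what lies behind this result.

The compounds shown leave open what a group other than these two halogens would do at this carbon, such as a methoxy, a nitrile or a plain hydrogen. They also leave open whether fluoro and chloro would still read alike with cyclohexylmethyl, as in compound 2, in place of pentan-3-yl on the aromatic nitrogen.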